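Removing a Methyl From Two Inactive Nitrile Compounds

The compounds below may be only part of what the source reports. "The series", "measured", "known", "first", "only" and "open" are said of these compounds alone.

Compound 1 `COCCOCn1cc(C#N)c2c(N)ncnc21`: > 100000 nM
Compound 2 `CNc1c(C#N)c2c(N)ncnc2n1COCCOC`: > 100000 nM

In a functional assay on KB cells (Homo sapiens) for inhibition (a lower number here means a stronger inhibitor, a higher number a weaker inhibitor), compound 1 gives > 100000 nM, which is a limit of the assay and not a number. In this assay compound 2 gives > 100000 nM, again a limit rather than a measured number. The step that the two limits leave unreadable from compound 1 to compound 2 therefore cannot be read because of the limit of > 100000 nM in this assay, at which 2 of the 2 values shown sit. Among the compounds with values here, compound 2 thus stands at the limit; nothing more than that limit is known of it, and no pattern can be drawn from only two such values.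

Compound 3 `COCCOCn1c(N)c(C#N)c2c(N)ncnc21` differs from compound 2 in one place: hydrogen in place of methyl on a nitrogen on an aromatic ring. Within the data shown here, no measured step concerns this nitrogen, and the only measured step at all is unreadable, so no size or direction can be taken from the data for this assay. Since compound 2 gives only a limit, compound 3 is expected to stay at or near that limit as well, an estimate of 100000 nM with a range of 30000 nM to 300000 nM. The expected step of a number no higher from compound 2 to compound 3 (the limit leaves the size open) is accordingly none beyond the scatter.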

Compound 3, half-maximal inhibitory concentration: 210000 nM
Compound 3: the middle estimate sits 2.1-fold (0.32 log units) below what was measured; the range from low to high includes it.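

Within the data shown here, no step among compound 1, compound 2 and compound 3 can be read, because compound 1 and compound 2 each give only a limit of the assay and not a number: the limit of > 100000 nM in this assay, at which 2 of the 3 values shown sit. The compounds shown leave open what size of change, if any, the amino or methylamino group brings in this assay.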